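Chloro for methoxy on the outer ring of compound 1

The compounds below may be only part of what the source reports. "The series", "measured", "known", "first", "only" and "open" are said of these compounds alone.

Working notes on the series. Two compounds have numbers in an assay on microsomes from Testis (strain Sprague-Dawley) for inhibition of steroid 17-alpha-hydroxylase/17,20 lyase (Rattus norvegicus); a higher number here means a weaker inhibitor, a lower number a stronger inhibitor. Compound 1 `COc1ccc(-c2ccc(C(O)(c3c[nH]cn3)C(C)C)cc2)cc1` gives 120 nM in this assay, the highest of the two numbers shown. Among the compounds with values here, compound 2 `CC(C)C(O)(c1cccc(-c2ccc(F)cc2)c1)c1c[nH]cn1` gives 8.3 nM in this assay, a lower number that lies beyond the scatter; compound 2 differs from compound 1 in more than one place, so no single step is read from that pair.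

Compound 3 `CC(C)C(O)(c1ccc(-c2ccc(Cl)cc2)cc1)c1c[nH]cn1` is not yet measured in this assay. It differs from compound 1 by chloro in place of methoxy on an aromatic carbon. Within the data shown here, no measured step of this kind stands. The expectation for compound 3 in this assay is a moderate step towards a lower number, a 2.4-fold lower number from compound 1 to compound 3 (0.38 log units; beyond the scatter), with a real chance of no change beyond the scatter. The estimate for compound 3 in this assay is 50 nM, in a range from 15 nM to 200 nM.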

Compound 3, half-maximal inhibitory concentration: 29 nM
Beside the measured number, compound 3's estimate is 1.7-fold (0.24 log units) above it; the measured number falls inside the stated range.
By their numbers in this assay, from the lowest: compound 2; then compound 3; then compound 1.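

In this assay, within the data shown here, the change from 4-methoxyphenyl to 4-chlorophenyl gives a 4.1-fold lower number from compound 1 to compound 3 (0.62 log units; beyond the scatter), the first single-place step, and shows that the aromatic carbon para to a large group on the outer ring responds to its substituent. At this position, the hydrogen-bond acceptor and the oxygen of the methoxy are not needed for the lower number, since chloro carries neither. No measured data on either group bear on why the number falls.

On these data alone, compound 2 differs from both compound 1 and compound 3 in more than one place, so it gives no reading of this position, and whether the same change would have a similar effect on its core remains open. Also open, as far as these compounds go, is how an amine, a carboxylic acid or a longer chain such as ethoxy would fare at this position.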